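The compounds below may be only part of what the source reports. "The series", "measured", "known", "first", "only" and "open" are said of these compounds alone.

Measured in an ADME assay (Rattus norvegicus, strain Wistar Han) for metabolic stability; a higher number here means that the compound lasts longer, a lower number that the compound disappears faster:
- compound 1 `CCn1ncc(-c2nc3c(O[C@H]4CCN(C(=O)C5CC5)C4)ncnc3n2C)c1C`: 0.4 h
- compound 2 `CCC(=O)N1CC[C@H](Nc2ncnc3c2nc(-c2cnn(CC)c2C)n3C)C1`: 0.4 h
- compound 3 `CCn1ncc(-c2nc3c(N4CCC(n5c(=O)[nH]c6ncccc65)CC4)ncnc3n2C)c1C`: 1.2 h

Compound 1 and compound 2 are level, and together they hold the lowest number of the three. Compound 3 lies beyond the scatter above compound 2.

Compound 4 `CCn1ncc(-c2nc3c(N[C@H]4CCN(C(=O)C5CCOCC5)C4)ncnc3n2C)c1C` departs from compound 2 in one place: oxan-4-yl in place of ethyl on a carbonyl carbon. It has oxan-4-yl in place of ethyl on a carbonyl carbon.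

Among the compounds with values here, no measured pair shows this change on its own, so only a weak expectation is possible in this assay: a small upward move at most, with none beyond the scatter. The expected step is a 1.3-fold higher number from compound 2 to compound 4 (0.10 log units; within the scatter). For compound 4 the estimate is 0.5 h, with an expected range of 0.25 h to 1 h.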

Compound 4, half-life: 0.2 h
Estimate against measurement, compound 4: 2.5-fold (0.40 log units) above; measured number below the stated range.
By their numbers in this assay, from the lowest: compounds 4, 1 and 2 (each within the scatter of the next); then compound 3.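

In this assay the change from ethyl to oxan-4-yl on a carbonyl carbon gives a 2.0-fold lower number from compound 2 to compound 4 (0.30 log units; within the scatter). This position therefore accepts a group with a six-membered non-aromatic ring and a hydrogen-bond acceptor without a step beyond the scatter, but the larger group brings no gain in half-life. Nothing measured here explains the result.

Going by these compounds, whether an amine, a carboxylic acid or a longer chain in this place would move the half-life beyond the scatter remains open.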